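The source may hold more compounds than are shown below. What is called first, only, known or untested is meant among the compounds shown, and "the series" means these compounds.

Compound 1 `CCCc1nc(-c2ccccc2)c(CNCCN2CCN(c3ccc(F)cc3)CC2)o1` stands second highest of the three numbers in an assay on HEK293 cells for inhibition of Voltage-dependent T-type calcium channel subunit alpha-1G (Homo sapiens), read by patch clamp (on this read-out lower numbers stand for stronger inhibition and higher numbers for weaker inhibition), where compound 1 gives 7080 nM. Compound 2 `CCCc1nc(-c2ccccc2)c(CNCCCN2CCN(c3ccc(C(F)(F)F)cc3)CC2)o1` gives 7250 nM in this assay, a value within the scatter of compound 1, while compound 3 `CCCc1nc(-c2ccccc2)c(CNCCCN2CCN(c3cccc(C)c3C)CC2)o1` gives 1780 nM, beyond the scatter to the lower side. Compound 4 `CCCc1nc(-c2ccccc2)c(CNCCN2CCN(c3ccccc3)CC2)o1` differs from compound 1 by hydrogen in place of fluoro on an aromatic carbon; cut one bond further out, the change reads 4-fluorophenyl to phenyl. Among the measured compounds shown here, the only measured step that touches the aryl group on the ring nitrogen is a 4.1-fold lower number from compound 2 to compound 3 (0.61 log units; beyond the scatter), a swap of the whole substitution pattern rather than the loss of a single fluoro. For the measured compounds named here, no measured pair shows what removing a lone fluoro does here. Going by the values given here, the change is small, and the one related step was only modest. Compound 4 is therefore expected to stay close to its parent, with an expected step of a 1.1-fold higher number from compound 1 to compound 4 (0.03 log units; within the scatter) that need not exceed the scatter. Compound 4 is estimated at 7500 nM in this assay, within 3000 nM to 18000 nM.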

Compound 4, half-maximal inhibitory concentration: 10300 nM
For compound 4 the middle estimate is 1.4-fold (0.14 log units) below the measured one; the range from low to high includes it.
By their numbers in this assay, from the lowest: compound 3; then compounds 1, 2 and 4 (each within the scatter of the next).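

In this assay, among the compounds shown here, the step of a 1.5-fold higher number from compound 1 to compound 4 (0.16 log units; within the scatter) gives the first reading of a lone fluoro on this aromatic carbon, para to a large group. Taking 4-fluorophenyl to phenyl leaves the number within the scatter, so the loss of this one atom shows no measurable change here, whereas the wider swap of the aryl group in a 4.1-fold lower number from compound 2 to compound 3 (0.61 log units; beyond the scatter) lies beyond the scatter. Nothing in the data at hand bears on this result.

The compounds shown leave open whether a chloro or a methoxy group on this same carbon would give a step beyond the scatter. They also leave open whether the change from 4-fluorophenyl to phenyl would read the same on the chain that compound 2 and compound 3 carry.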